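The source may hold more compounds than are shown below. What is called first, only, known or untested is meant among the compounds shown, and "the series" means these compounds.

Measured so far:
- compound 1, `CC(C)CNC(=O)[C@H](C)NC(=O)[C@]1(Cc2ccccc2)CCN1C(=O)OCc1ccccc1`: in an ADME assay on HELF cells (Homo sapiens) for cytotoxicity, with a stated time of 3 days (on this read-out lower numbers stand for higher toxicity in this test and higher numbers for lower toxicity in this test), compound 1 gives only a limit, > 100000 nM.
- compound 2, `C[C@H](NC(=O)[C@@]1(Cc2ccccc2)CCN1C(=O)OCc1ccccc1)C(=O)NCc1ccccc1`: in this assay compound 2 gives 42000 nM.
- compound 3, `C[C@H](NC(=O)[C@@]1(Cc2ccccc2)CCN1C(=O)OCc1ccccc1)C(=O)NC1CCCCC1`: in this assay compound 3 gives 46000 nM.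

Among the two numbers compound 3 has the higher one, yet its only neighbour is compound 2, and the step of a 1.1-fold higher number from compound 2 to compound 3 (0.04 log units; within the scatter) lies within the scatter, so no order between the two can be read. The value of compound 1 is a limit of the test, (the limit of > 100000 nM in this assay, at which 1 of the 3 values shown sits), and not a number.

Compound 4, `CC(C)CNC(=O)[C@H](C)NC(=O)[C@@]1(Cc2ccccc2)CCN1C(=O)OCc1ccccc1`, differs from compound 3 in one place: isobutyl in place of cyclohexyl on an amide-type nitrogen. Going by the values given here, no measured step exchanges these two groups directly. Among the compounds with values here, the one measured step at this amide nitrogen, a 1.1-fold higher number from compound 2 to compound 3 (0.04 log units; within the scatter), stayed within the scatter and gives no sign that the group on this nitrogen moves the read-out. Compound 4 is therefore expected to sit close to compound 3, with a step of a 1.3-fold higher number from compound 3 to compound 4 (0.12 log units; within the scatter). The estimate for compound 4 in this assay is 60000 nM, from 25000 nM to 150000 nM, and a limit rather than a number is possible.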

Compound 4, half-maximal cytotoxic concentration: > 100000 nM
Compound 4: no number, only a limit; the forecaster's own chance of this, stated with the estimate: 35%; middle value at least 1.6-fold (0.22 log units) away from the limit.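

In this assay compound 4 gives only a limit, not a number: the limit of > 100000 nM in this assay, at which 2 of the 4 values shown sit. The group on the amide-type nitrogen does matter here after all, since isobutyl gives an at least 2.1-fold higher number from compound 3 to compound 4 (0.33 log units; beyond the scatter) and an at least 2.3-fold higher number from compound 2 to compound 4 (0.37 log units; beyond the scatter), whereas the two groups with a ring differed only by a 1.1-fold higher number from compound 2 to compound 3 (0.04 log units; within the scatter). Compound 1 and compound 4 both end in limits, so the step between them cannot be read and the drawn configuration cannot be judged from this pair: the fact that compounds 1 and 4 differ only in the configuration as drawn.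

On these data alone, how far beyond the limit compound 4 lies stays open, so the true size of both steps is unknown. Also open, as far as these compounds go, is whether a longer chain, or a chain carrying an amine, on this nitrogen would reach the same limit as isobutyl.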